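Inverting the ring stereocentre of compound 3

The source may report more compounds than this note shows. Statements on the series, on what has been measured and on what is new or still open speak of the compounds shown alone.

In a functional assay for inhibition, with Homo sapiens as the target (a higher number here means a weaker inhibitor, a lower number a stronger inhibitor), compound 1 `N=C(N)NCCC[C@@H]1NC(=O)N(CC(=O)N[C@@H](CC(=O)O)C(=O)N[C@@H](CO)C(=O)O)C1=O` gives 10000 nM as the highest number. Compound 2 `CC1(c2ccc(C(=N)N)cc2)NC(=O)N(CC(=O)NC(CC(=O)O)c2ccccc2)C1=O` stands lower at 200 nM and compound 3 `C[C@@]1(c2ccc(C(=N)N)cc2)NC(=O)N(CC(=O)N[C@@H](CC(=O)O)c2ccccc2)C1=O` stands lowest at 20 nM with both of its gaps beyond the scatter.

Compound 4 `C[C@]1(c2ccc(C(=N)N)cc2)NC(=O)N(CC(=O)N[C@@H](CC(=O)O)c2ccccc2)C1=O` is the next case. The change is the two compounds have the same atoms and bonds; at least one stereo element is drawn with a configuration in one of them and without one in the other: 1 of 3 stereo elements differ; a stereocentre at a saturated ring carbon is drawn S in compound 3 and R in compound 4 with a stereocentre at a saturated ring carbon drawn S in compound 3 and R in compound 4.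

Among the compounds with values here, one measured step bears on this. It is a 10-fold lower number from compound 2 to compound 3 (1.00 log units; beyond the scatter) and what separates that pair is the fact that one of compounds 2 and 3 is drawn with a defined configuration and the other without, at the place where they differ at the ring carbon and at a chain carbon together. Since the form without defined centres sits above compound 3 by that step, at least some undefined form should be weaker, and compound 4 may be one of them. A higher number is therefore expected in this assay with an estimated 20-fold higher number from compound 3 to compound 4 (1.30 log units; beyond the scatter) beyond the scatter. For compound 4 the estimated value is 400 nM with an expected range from 80 nM to 3000 nM at this stage.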

Compound 4, half-maximal inhibitory concentration: 6000 nM
Beside the measured number, compound 4's estimate is 15-fold (1.18 log units) below it; measured number outside the range, above it.
By their numbers in this assay, from the lowest: compound 3; then compound 2; then compounds 4 and 1 (each within the scatter of the next).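

With the saturated chain carbon drawn S in both compounds, inverting the saturated ring carbon alone gives a 300-fold higher number from compound 3 to compound 4 (2.48 log units; beyond the scatter) in this assay, so this single stereocentre now accounts for a large change in its own right. The earlier step had changed the ring carbon and the chain carbon together and could not separate them. Compound 2, drawn without either configuration, also stands clear of the R compound, with a 30-fold higher number from compound 2 to compound 4 (1.48 log units; beyond the scatter), and the comparison of the two defined compounds rests on one place only: the fact that one of compounds 3 and 4 is drawn with a defined configuration and the other without, at the place where they differ

The compounds shown leave open what the saturated chain carbon contributes on its own. They also leave open whether an ethyl group in place of the methyl at the saturated ring carbon would keep the same gap between the S and R forms.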